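The compounds below may be only part of what the source reports. "The series", "measured", "known", "first", "only" and "open" are said of these compounds alone.

In an assay on HEK293 cells for inhibition of sodium- and chloride-dependent glycine transporter 1 (Homo sapiens), read by scintillation proximity assay (a higher number here means a weaker inhibitor, a lower number a stronger inhibitor), compound 1, with structure `O=C(CN(CC1CC1)C(=O)c1ccc(-c2ccccn2)cc1)Nc1cc(F)cc(F)c1`, gives 200 nM. Going by the values given here, compound 2, with structure `O=C(CN(C(=O)c1ccc(-c2ccccn2)cc1)C1CCOCC1)Nc1cc(F)cc(F)c1`, gives 1000 nM in this assay, the higher of the two numbers so far; the only step measured, a 5.0-fold higher number from compound 1 to compound 2 (0.70 log units; beyond the scatter), is the change that separates them. Compound 3, with structure `O=C(CN(C(=O)c1ccc(-c2ccccn2)cc1)C1CCOC1)Nc1cc(F)cc(F)c1`, differs from compound 2 by oxolan-3-yl in place of oxan-4-yl on an amide-type nitrogen. Among the compounds with values here, no measured step touches this exact exchange, so the expectation is for at most a small movement, with no clear direction beyond the scatter. Compound 3 is therefore estimated at 700 nM, within 250 nM to 2500 nM, a step of a 1.4-fold lower number from compound 2 to compound 3 (0.15 log units; within the scatter) expected from compound 2.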

Compound 3, half-maximal inhibitory concentration: 1260 nM
Beside the measured number, compound 3's estimate is 1.8-fold (0.26 log units) below it, and the stated range covers the measured number.
By their numbers in this assay, from the lowest: compound 1; then compounds 2 and 3 (each within the scatter of the next).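

Oxolan-3-yl and oxan-4-yl on the amide-type nitrogen cannot be told apart here, with a 1.3-fold higher number from compound 2 to compound 3 (0.10 log units; within the scatter) as the step between them. The five-membered ring also stands clear of cyclopropylmethyl, with a 6.3-fold higher number from compound 1 to compound 3 (0.80 log units; beyond the scatter) as its step, so both oxygen-containing rings shown give higher numbers than cyclopropylmethyl. Nothing available explains these results.

Cyclohexyl, an all-carbon ring, remains open: it could separate the ring oxygen's part from that of ring size. So does a piperidin-4-yl amine at this nitrogen.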